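The compounds below may be only part of what the source reports. "The series", "measured", "known", "first", "only" and "open" are said of these compounds alone.

Three compounds share one core and differ only at the sulfonamide nitrogen. In a functional assay on the whole organism (strain STD-dd) with Mus musculus as the target, in the maximal electroshock model, with a stated time of 2 h (on this read-out lower numbers stand for an effect already at smaller amounts and higher numbers for an effect only at larger amounts of compound), compound 1 `CNS(=O)(=O)Cc1noc2ccc(Br)cc12` gives 15 mg/kg. Compound 2 `CCNS(=O)(=O)Cc1noc2ccc(Br)cc12` gives 18 mg/kg. Compound 3 `CN(C)S(=O)(=O)Cc1noc2ccc(Br)cc12` gives 45 mg/kg, the highest of the three numbers, reached by a 2.5-fold higher number from compound 2 to compound 3 (0.40 log units; beyond the scatter) and by a 3.0-fold higher number from compound 1 to compound 3 (0.48 log units; beyond the scatter). Compound 4 `CN1CCN(S(=O)(=O)Cc2noc3ccc(Br)cc23)CC1` carries 4-methylpiperazin-1-yl in place of dimethylamino on a sulfonyl sulfur. The measured steps that bear on this are a 3.0-fold higher number from compound 1 to compound 3 (0.48 log units; beyond the scatter), methyl in place of hydrogen on a sulfonamide nitrogen, and a 2.5-fold higher number from compound 2 to compound 3 (0.40 log units; beyond the scatter), both modest rises. Compound 4 keeps two substituents on that nitrogen, so a further modest rise or no step beyond the scatter is expected. Compound 4 is therefore estimated at 65 mg/kg, between 30 mg/kg and 150 mg/kg, an expected step of a 1.4-fold higher number from compound 3 to compound 4 (0.16 log units; within the scatter).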

Compound 4, dose for half-maximal effect: 88 mg/kg
Estimate against measurement, compound 4: 1.4-fold (0.13 log units) below; the measured number falls inside the stated range.
By their numbers in this assay, from the lowest: compounds 1 and 2 (each within the scatter of the next); then compounds 3 and 4 (each within the scatter of the next).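

On a sulfonyl sulfur, 4-methylpiperazin-1-yl can replace dimethylamino without a step beyond the scatter (a 2.0-fold higher number from compound 3 to compound 4 (0.29 log units; within the scatter)), so adding a six-membered ring and a hydrogen-bond acceptor here does not separate these two compounds. Compared with the groups that keep a hydrogen on the sulfonamide nitrogen, the ring gives larger steps (a 4.9-fold higher number from compound 2 to compound 4 (0.69 log units; beyond the scatter); a 5.9-fold higher number from compound 1 to compound 4 (0.77 log units; beyond the scatter)). No measured evidence accounts for these steps. The compounds shown leave open whether piperidin-1-yl or morpholin-4-yl would behave like 4-methylpiperazin-1-yl. They also leave open where a plain amino group on the sulfonyl sulfur would fall.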